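The source may report more compounds than this note shows. Statements on the series, on what has been measured and on what is new or still open speak of the compounds shown alone.

Compound 1 `CCC(=O)Nc1ccc(C(=O)Nc2ccc(C)c(Nc3nccc(-c4cccnc4)n3)c2)cc1` was examined in an ADME assay on BaF3 cells (Mus musculus) for cytotoxicity, read by CellTiter-Glo and CCK-8 assay, with a stated time of 72 h; a higher number here means a weaker inhibitor of growth, a lower number a stronger inhibitor of growth. In this assay compound 1 gives > 10000 nM, which is a limit of the assay rather than a number. Compound 2 `Cc1ccc(NC(=O)c2ccc(CN(CCN3CCCC3)C(=O)c3cccnc3)cc2)cc1Nc1nccc(-c2cccnc2)n1` gives > 10000 nM in this assay, again a limit. Both measured values sit at the limit of > 10000 nM in this assay, at which 2 of the 2 values shown sit, so compound 1 cannot be ordered against compound 2. Compound 3 `C=CC(=O)N(CCC(C)C)Cc1ccc(C(=O)Nc2ccc(C)c(Nc3nccc(-c4cccnc4)n3)c2)cc1` differs from compound 1 by (isopentyl(vinylcarbonyl)amino)methyl in place of propanoylamino on an aromatic carbon. Among the compounds with values here, no measured step bears on this change, so in this assay a shift beyond the scatter toward stronger inhibition is possible but unanchored. Compound 3 is expected to give 6000 nM, between 1500 nM and 20000 nM, an estimated step of an at least 1.6-fold lower number from compound 1 to compound 3 (0.22 log units; that floor lies within the scatter).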

Compound 3, concentration for 50% growth inhibition: 5620 nM
The estimate for compound 3 lay 1.1-fold (0.03 log units) above the measured number; the measured number falls inside the stated range.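

In this assay compound 3 gives 5620 nM as a number and not a limit, which sets it apart from the other compounds shown: the limit of > 10000 nM in this assay, at which 2 of the 3 values shown sit. The change to (isopentyl(vinylcarbonyl)amino)methyl in place of propanoylamino at this position gives an at least 1.7-fold lower number from compound 1 to compound 3 (0.25 log units; that floor lies within the scatter) and no more than that floor can be read, since compound 1 stands at a limit.

The compounds shown leave open whether the isopentyl chain or the vinylcarbonyl carries the step. A propanoyl on the same nitrogen, or an amine in place of the isopentyl chain, would separate the two.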